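Chloro for iodo on the aniline ring of compound 1

The source may report more compounds than this note shows. Statements on the series, on what has been measured and on what is new or still open speak of the compounds shown alone.

Measured compounds:
compound 1, `Nc1ccc(-c2nc3cc(F)ccc3s2)cc1I`, 130 nM
compound 2, `Cc1cc(-c2nc3ccc(F)cc3s2)ccc1N`, no result reported
compound 3, `Cc1cc(-c2nc3cccc(F)c3s2)ccc1N`, 20 nM

In a functional assay on T47D cells (Breast, Homo sapiens) for inhibition (on this read-out higher numbers stand for weaker inhibition of growth and lower numbers for stronger inhibition of growth), compound 1 gives 130 nM, the highest of the two numbers available; compound 3 sits at a lower number, beyond the scatter, while compound 2 gives no result reported in this assay. Within the data shown here, no step between measured compounds is available, and the fluorine sits differently on the core in each, so nothing ties compound 1 directly to compound 3.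

Compound 4, `Nc1ccc(-c2nc3cc(F)ccc3s2)cc1Cl`, differs from compound 1 by chloro in place of iodo on an aromatic carbon. With no measured step of this kind in the series, the step of a 1.5-fold higher number from compound 1 to compound 4 (0.19 log units; within the scatter) is an estimate only, expected small and within the scatter, leaning towards weaker inhibition. Compound 4 is thus expected at 200 nM in this assay, within 60 nM to 700 nM.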

Compound 4, concentration for 50% growth inhibition: 40 nM
Beside the measured number, compound 4's estimate is 5.0-fold (0.70 log units) above it, outside the stated range (below it).
By their numbers in this assay, from the lowest: compounds 3 and 4 (each within the scatter of the next); then compound 1.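

In this assay, among these compounds, the place ortho to an amino group gives the first readable step, with chloro in place of iodo showing a 3.3-fold lower number from compound 1 to compound 4 (0.51 log units; beyond the scatter) and a gain in inhibition of growth beyond the scatter. This position on the core of compound 1 is therefore sensitive to the choice of halogen. Nothing available accounts for the difference. Still open, going by these compounds, is how bromo, methoxy or nitrile would read at this place on the same core. Also open, on these data alone, is whether the step holds with the fluorine elsewhere on the core.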